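A few compounds are considered here, and "the series" means these few. Any claim that something is new, unique, unknown or untested is made for them only; others in the source may bear on it.

Measured in a functional assay on NFS-60 cells (Mus musculus) for inhibition, with a stated time of 72 h; a higher number here means a weaker inhibitor of growth, a lower number a stronger inhibitor of growth:
- compound 1 `COc1ccc(Cn2nc(Br)c3c(NC(=O)c4csc5c(N)ncnc45)cccc32)cc1`: 2390 nM
- compound 2 `Nc1ncnc2c(C(=O)Nc3cccc4c3c(Br)nn4Cc3ccccn3)csc12`: 2500 nM
- compound 3 `Nc1ncnc2c(C(=O)Nc3cccc4c3c(Br)nn4Cc3cccnc3)csc12`: 77 nM

Compound 3 holds the lowest of the three numbers and is the strongest inhibitor of growth so far. The other two cannot be told apart, with a 1.0-fold higher number from compound 1 to compound 2 (0.02 log units; within the scatter). Against them, the group on the saturated chain carbon matters a great deal: a 31-fold lower number from compound 1 to compound 3 (1.49 log units; beyond the scatter), and a 32-fold lower number from compound 2 to compound 3 (1.51 log units; beyond the scatter).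

The next compound is compound 4 `Nc1ncnc2c(C(=O)Nc3cccc4c3c(Br)nn4Cc3cccc(F)n3)csc12`. The change is 6-fluoropyridin-2-yl in place of pyridin-3-yl on a saturated chain carbon bound to an aromatic nitrogen. In words, 6-fluoropyridin-2-yl stands in place of pyridin-3-yl on a saturated chain carbon bound to an aromatic nitrogen.

The most relevant measured step is a 32-fold lower number from compound 2 to compound 3 (1.51 log units; beyond the scatter), since compound 4 returns to a pyridin-2-yl attachment. Read backwards, that step points to a large rise in this assay. For the measured compounds named here, no measured compound tests the fluorine, and the evidence for the pyridine attachment rests on this single pair, so the full size of that step cannot simply be carried over. A somewhat smaller rise, still beyond the scatter, is the working expectation.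

The expected change is a 10-fold higher number from compound 3 to compound 4 (1.02 log units; beyond the scatter). Compound 4 is estimated at 800 nM, with an expected range of 150 nM to 3500 nM.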

Compound 4, concentration for 50% growth inhibition: 233 nM
Beside the measured number, compound 4's estimate is 3.4-fold (0.54 log units) above it; low and high end bracket the measured number.
By their numbers in this assay, from the lowest: compound 3; then compound 4; then compounds 1 and 2 (each within the scatter of the next).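

In this assay, the fluoro in place of hydrogen on an aromatic carbon recovers much of what the pyridin-2-yl attachment had lost (an 11-fold lower number from compound 2 to compound 4 (1.03 log units; beyond the scatter)), so at this position the number depends on more than where the pyridine is attached, which compounds 1 to 3 could not show. The recovery is incomplete, since 6-fluoropyridin-2-yl still gives up ground to pyridin-3-yl (a 3.0-fold higher number from compound 3 to compound 4 (0.48 log units; beyond the scatter)) while standing well clear of 4-methoxyphenyl (a 10-fold lower number from compound 1 to compound 4 (1.01 log units; beyond the scatter)), which places compound 4 in the middle of the series and leaves compound 3 with the lowest number. Nothing measured in this set gives a reason for the effect of the fluoro or for the gap that remains.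

Still open, going by these compounds, is whether a fluoro on the pyridin-3-yl group would lower the number further or raise it, and whether the gain belongs to the fluoro itself or would also appear with a chloro, a methyl or an amine in its place. On these data alone, all of this rests on a single fluoro pair in one growth read-out, so its reach across other groups on the saturated chain carbon remains unknown.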